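The source may hold more compounds than are shown below. What is called first, only, known or untested is meant among the compounds shown, and "the series" means these compounds.

Compound 1 `Cc1nc(N)c2c(-c3ccccc3)cn([C@@H]3O[C@H](CO)[C@@H](O)[C@H]3O)c2n1`: in a functional assay on HeLa S3 cells (Homo sapiens) for antiproliferative activity, read by XTT assay, with a stated time of 72 h (on this read-out higher numbers stand for weaker inhibition and lower numbers for stronger inhibition), compound 1 gives > 20000 nM, which is a limit of the assay.
Compound 2 `Cc1nc(N)c2c(-c3cccs3)cn([C@@H]3O[C@H](CO)[C@@H](O)[C@H]3O)c2n1`: in this assay compound 2 gives > 20000 nM, also a limit.
Compound 3 `CNc1ncnc2c1c(-c1ccccc1)cn2[C@@H]1O[C@H](CO)[C@@H](O)[C@H]1O`: in this assay compound 3 gives > 20000 nM, again a limit.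

Compounds 1 and 2 share a core and differ by one change, (thiophen-2-yl in place of phenyl on an aromatic carbon). Both values are limits, and the step that the two limits leave unreadable from compound 1 to compound 2 therefore has no readable size; all that can be said is the limit of > 20000 nM in this assay, at which 3 of the 3 values shown sit. Compound 3 has the same atoms as compound 1 joined differently, and the difference between the two cores is not broken down here. Compound 4 `CNc1ncnc2c1c(-c1cccs1)cn2[C@@H]1O[C@H](CO)[C@@H](O)[C@H]1O` stands to compound 3 as compound 2 stands to compound 1: it carries the same change, (thiophen-2-yl in place of phenyl on an aromatic carbon), at the same place. The earlier step is unreadable, and compound 3 itself sits at the limit, so no measured size can be carried over. The step from compound 3 to compound 4 is expected to be a step that the limit leaves unreadable from compound 3 to compound 4, an expectation resting only on (the limit of > 20000 nM in this assay, at which 3 of the 3 values shown sit). Compound 4 is accordingly expected to give 30000 nM in this assay, within a range from 12000 nM to 150000 nM.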

Compound 4, half-maximal inhibitory concentration: > 20000 nM
Compound 4 was reported as a limit; the forecaster's own chance of this, stated with the estimate: 85%; the middle value is on the limit's open side.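

In this assay compound 4 gives > 20000 nM as a limit of the assay. Going by these compounds alone, compound 3 also stands at a limit, so no step from compound 3 to compound 4 can be read. The compounds shown leave open whether thiophen-2-yl in place of phenyl changes the activity at all, and every value sits at the same limit: the limit of > 20000 nM in this assay, at which 4 of the 4 values shown sit.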